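Hydroxy in place of hydrogen on a fused core

The compounds below may be only part of what the source reports. "The series", "measured", "known", "first", "only" and "open" are said of these compounds alone.

Compound 1 `Cc1cc(O[C@@H](C)c2c(Cl)ccc(F)c2Cl)ccc1/C=C/C(=O)O` gives 3.2 in a physicochemical assay for lipophilicity, using the shake flask method; on this read-out higher numbers stand for higher lipophilicity and lower numbers for lower lipophilicity. Compound 2 `C[C@H](Oc1ccc2ncc(/C=C/C(=O)O)c(-n3ccnc3)c2c1)c1c(Cl)ccc(F)c1Cl` gives 2 in this assay, and compound 3 `C[C@H](Oc1ccc2ncc(/C=C/C(=O)O)cc2c1)c1c(Cl)ccc(F)c1Cl` gives 2.5. Compound 3 thus stands second highest of the three numbers, lying a number 0.50 log units higher from compound 2 to compound 3 (beyond the scatter) and below compound 1 by a wider margin. Compound 4 `C[C@H](Oc1ccc2ncc(/C=C/C(=O)O)c(O)c2c1)c1c(Cl)ccc(F)c1Cl` differs from compound 3 by hydroxy in place of hydrogen on an aromatic carbon. For the measured compounds named here, no measured pair shows this exact change, so the one step that bears on it only loosely is the one in which a ring substituent was removed, a number 0.50 log units higher from compound 2 to compound 3 (beyond the scatter), a modest rise on going to hydrogen. Here the change runs the other way: hydrogen leaves and a group with one hydrogen-bond donor and one hydrogen-bond acceptor enters. A modest fall beyond the scatter is therefore expected for compound 4, a number 0.40 log units lower from compound 3 to compound 4 (beyond the scatter). Compound 4 is estimated at 2.1 in this assay, with a likely range from 1.5 to 2.7.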

Compound 4, distribution coefficient: 1.9
Beside the measured number, compound 4's estimate is 0.20 log units above it, and the stated range covers the measured number.
By their numbers in this assay, from the lowest: compounds 4 and 2 (each within the scatter of the next); then compound 3; then compound 1.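

At this position, on an aromatic carbon ortho to a 2-carboxyethenyl group and opposite the ring nitrogen, the hydroxy change can now be read directly in this assay: the step is a number 0.60 log units lower from compound 3 to compound 4 (beyond the scatter), a modest one. The replacement of 1H-imidazol-1-yl by hydroxy at the same carbon gives a number 0.10 log units lower from compound 2 to compound 4 (within the scatter), so this assay does not separate these two groups, although each stands apart from hydrogen beyond the scatter. Nothing given here accounts for these steps.

As far as these compounds go, it remains open whether a methoxy group, an amine or a fluorine on this carbon would fall with hydroxy and 1H-imidazol-1-yl or with hydrogen. From the compounds shown here alone, whether hydroxy in place of hydrogen brings a similar step on the core of compound 1 also remains open.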